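Trimethoxyphenyl Pyrazole Enones: Adding a Methoxy Group

This account rests on a few compounds, and the source may have more. Where it says the series, first, only, none or still open, it means among the compounds named here.

Measured compounds: compound 1 `COc1cc(-c2cc(/C=C/C(=O)c3ccc(Cl)c(Cl)c3)[nH]n2)cc(OC)c1OC` 50900 nM; compound 2 `COc1ccc(-c2cc(/C=C/C(=O)c3cc(OC)c(OC)c(OC)c3)[nH]n2)cc1OC` 7170 nM; compound 3 `COc1ccc(C(=O)/C=C/c2cc(-c3cc(OC)c(OC)c(OC)c3)n[nH]2)cc1` 8320 nM.

In a functional assay on OVCAR-4 cells (Homo sapiens) for inhibition, read by sulforhodamine B assay, with a stated time of 48 h (on this read-out higher numbers stand for weaker inhibition of growth and lower numbers for stronger inhibition of growth), compound 2 gives the lowest of the three numbers, though compound 3 lies within the scatter of it; only compound 1 stands clearly apart. Compound 4 `COc1cc(C(=O)/C=C/c2cc(-c3cc(OC)c(OC)c(OC)c3)n[nH]2)cc(OC)c1OC` differs from compound 2 by methoxy in place of hydrogen on an aromatic carbon. For the measured compounds named here, the only measured step, a 6.1-fold lower number from compound 1 to compound 3 (0.79 log units; beyond the scatter), concerns the ring on the carbonyl carbon, not the ring where compound 4 changes, so no step bears directly on this change. A step within the scatter is therefore expected, a 1.0-fold lower number from compound 2 to compound 4 (0.01 log units; within the scatter). Compound 4 is estimated at 7000 nM, with a range from 3000 nM to 18000 nM.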

Compound 4, concentration for total growth inhibition: 2760 nM
For compound 4 the middle estimate is 2.5-fold (0.40 log units) above the measured one, and the stated range ends above it.
By their numbers in this assay, from the lowest: compound 4; then compounds 2 and 3 (each within the scatter of the next); then compound 1.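

In this assay, methoxy in place of hydrogen on this aromatic carbon, ortho to a methoxy group and meta to a large group, strengthens growth inhibition (a 2.6-fold lower number from compound 2 to compound 4 (0.41 log units; beyond the scatter)). This is the first step shown on the ring away from the carbonyl, and it shows that this position responds to substitution, a change beyond the scatter. No measurement shown here accounts for the gain. On these data alone, whether an amine or a longer chain such as ethoxy at this position would do the same remains open, as does whether the methoxy gain holds when the ring on the carbonyl carbon differs.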